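Ethoxy for ethyl on the shared core: compound 4 ahead

The source may hold more compounds than are shown below. What is called first, only, known or untested is meant among the compounds shown, and "the series" means these compounds.

Measured so far:
Compound 1 `Fc1cncc(OC[C@@H]2CCN2)c1` gives 0.076 nM in an assay on brain for binding affinity to Neuronal acetylcholine receptor; alpha4/beta2 (Rattus norvegicus), read by radioligand binding; a lower number here means a stronger inhibitor, a higher number a weaker inhibitor.
Compound 2 `N#Cc1cncc(OC[C@@H]2CCN2)c1` gives 0.025 nM in this assay.
Compound 3 `CCc1cncc(OC[C@@H]2CCN2)c1` gives 0.1 nM in this assay.

Compound 3 is separated from compound 2 by a 4.0-fold higher number from compound 2 to compound 3 (0.60 log units; beyond the scatter), beyond the scatter, while a 1.3-fold higher number from compound 1 to compound 3 (0.12 log units; within the scatter) lies within the scatter, so compound 3 and compound 1 cannot be told apart on these numbers. The one substituent that stands out is cyano, as a 3.0-fold lower number from compound 1 to compound 2 (0.48 log units; beyond the scatter) shows.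

Compound 4 `CCOc1cncc(OC[C@@H]2CCN2)c1` is the next member: ethoxy in place of ethyl on an aromatic carbon. Within the data shown here, none of the measured steps swaps an alkyl group for an alkoxy group, so the change has no direct precedent here. Among the measured compounds shown here, the steps that bear on it only show that fluoro and ethyl sit together within the scatter and that cyano alone pulls the number down. Ethoxy is not cyano, and nothing in the series argues for a large move either way; the expectation is therefore a 1.3-fold lower number from compound 3 to compound 4 (0.10 log units; within the scatter), no step beyond the scatter. Compound 4 is estimated at 0.08 nM in this assay, with a range from 0.03 nM to 0.25 nM.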

Compound 4, inhibition constant: 0.039 nM
Compound 4: middle estimate off by 2.1-fold (0.31 log units), on the high side, and the stated range covers the measured number.
By their numbers in this assay, from the lowest: compounds 2, 4, 1 and 3 (each within the scatter of the next, the first and the last beyond it).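

In this assay, among these compounds, the change from ethyl to ethoxy at this position moves the number beyond the scatter (a 2.6-fold lower number from compound 3 to compound 4 (0.41 log units; beyond the scatter)), the first step here that separates a non-cyano group from ethyl. Cyano no longer stands apart, as ethoxy cannot be told from it (a 1.6-fold higher number from compound 2 to compound 4 (0.19 log units; within the scatter)), and ethoxy also cannot be told from fluoro (a 1.9-fold lower number from compound 1 to compound 4 (0.29 log units; within the scatter)), even though fluoro and ethyl likewise lie within the scatter of each other. No measurement at hand explains why this change moves the number.

The compounds shown leave open whether the step follows the ring-bound oxygen or the extra heavy atom, which a comparison of ethoxy with propyl could separate. They also leave open how methoxy, propoxy or an amine would read at this position.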